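Methylation of the aromatic hydroxy group in a purine-like series

A few compounds are considered here, and "the series" means these few. Any claim that something is new, unique, unknown or untested is made for them only; others in the source may bear on it.

Among the compounds with values here, compound 2 `Nc1nc(O)nc2c1nc(O)n2Cc1ccccc1` stands level with compound 1 `CCCC[S+]([O-])c1nc(N)c2nc(O)n(Cc3ccccc3)c2n1` on the numbers so far: in a functional assay on the whole organism for activation, with Mus musculus as the target (on this read-out lower numbers stand for an effect already at smaller amounts and higher numbers for an effect only at larger amounts of compound), compound 1 gives 1 mg/kg and compound 2 gives 1 mg/kg. Within the data shown here, the single measured step, no change at the digits printed from compound 1 to compound 2 (within the scatter), exchanged one oxygen atom for a group of six heavy atoms on an aromatic carbon and left the read-out unchanged within the scatter, so the shared core tolerates a large alteration at that position without a shift in the dose needed.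

Compound 3 `COc1nc(N)c2nc(O)n(Cc3ccccc3)c2n1` is the next step from compound 2. The difference is methyl in place of hydrogen on an oxygen on an aromatic ring; cut one bond further out it reads hydroxy to methoxy. Among the measured compounds shown here, no measured pair tests exactly this change. For the measured compounds named here, the only step that bears on it is the one from compound 1 to compound 2 at the same aromatic carbon, which was flat; a methyl on that oxygen is a far smaller alteration than the one already tolerated. The expectation in this assay is therefore a step of no change at the digits printed from compound 2 to compound 3 (within the scatter), no change beyond the scatter. Compound 3 is estimated at 1 mg/kg, with a range of 0.3 mg/kg to 3 mg/kg.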

Compound 3, minimum effective dose: > 1 mg/kg
Compound 3: no number, only a limit; the forecaster's own chance of this, stated with the estimate: 10%; the middle value sits exactly at the limit.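

In this assay compound 3 carries > 1 mg/kg, which is a limit of the assay and not a number. Until now, the aromatic carbon had shown only a flat result, no change at the digits printed from compound 1 to compound 2 (within the scatter), whereas the methoxy group gives the first member at this position without a readable minimum effective dose, so that flat result cannot be extended to the methoxy group. The steps into compound 3 give a direction only and their sizes cannot be read: a number no lower from compound 2 to compound 3 (the limit leaves the size open) and a number no lower from compound 1 to compound 3 (the limit leaves the size open). The comparison stops at this point: the limit of > 1 mg/kg in this assay, at which 1 of the 3 values shown sits.

The compounds shown leave open whether the hydroxy to methoxy change has any real effect on the dose, or whether methoxy sits level with hydroxy and the limit merely hides that. Also open, going by these compounds, is how other groups on the same aromatic carbon would read out, such as an amine, an ethoxy group or a longer chain such as butoxy, and whether any of them would stay level with compound 1 and compound 2.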